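The source may report more compounds than this note shows. Statements on the series, on what has been measured and on what is new or still open speak of the compounds shown alone.

Measured so far in an assay on HEK-293T cells for antagonist activity at vitamin D3 receptor (Homo sapiens), read by a luciferase reporter, with a stated time of 24 h; a higher number here means a weaker inhibitor, a lower number a stronger inhibitor:
compound 1, `CC(C)c1onc(-c2c(Cl)cccc2Cl)c1COc1ccc(-c2nc3ccc(C(=O)O)cc3n2CC2CC2)cc1`: 2650 nM
compound 2, `CC(C)c1onc(-c2c(Cl)cccc2Cl)c1COc1ccc(-c2nc3ccc(C(=O)O)cc3n2C)c(Cl)c1`: 3520 nM

Two numbers are on hand, and they lie within the scatter of each other, so compound 1 does not stand apart from compound 2 in this assay and no order between them is claimed. Compound 2 differs from compound 1 in two places at once, so the pair gives no reading on any single change.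

The next compound is compound 3, `CC(C)c1onc(-c2c(Cl)cccc2Cl)c1COc1ccc(-c2nc3ccc(C(=O)O)cc3n2C2CCCC2)cc1`. Against compound 1 the difference is cyclopentyl in place of cyclopropylmethyl on an aromatic nitrogen. Within the data shown here, no measured pair isolates this position, so there is nothing to lean on beyond the near-equality of the two numbers already seen.

Expectation for compound 3 in this assay: a step of a 1.1-fold lower number from compound 1 to compound 3 (0.03 log units; within the scatter) is expected, that is none beyond the scatter, since the group on the aromatic nitrogen is swapped for one of similar kind and the rest of the structure is kept as in compound 1, which gave 2650 nM. The estimate for compound 3 is 2500 nM, with a range of 1000 nM to 6500 nM.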

Compound 3, half-maximal inhibitory concentration: 929 nM
Compound 3: the middle estimate sits 2.7-fold (0.43 log units) above what was measured, and the stated range ends above it.
By their numbers in this assay, from the lowest: compound 3; then compounds 1 and 2 (each within the scatter of the next).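

In this assay, among these compounds, the group on the aromatic nitrogen now has a reading of its own: cyclopentyl in place of cyclopropylmethyl gives a 2.9-fold lower number from compound 1 to compound 3 (0.46 log units; beyond the scatter) and is the first single change with a step beyond the scatter. The position therefore responds even to a swap between two groups of similar kind, both made of carbon only, both holding one non-aromatic ring and neither carrying a hydrogen-bond donor or acceptor, though this rests on one modest step from one pair. Nothing on hand bears on the cause of this step.

Going by these compounds, whether the lower number follows from the five-membered ring itself remains open, as a cyclohexyl group, an open chain such as isopropyl or a ring holding an amine such as piperidinyl would be needed to show how far the trend runs in either direction. Also open, on these data alone, is whether the same change carries over to the core of compound 2, where the group on the aromatic nitrogen is methyl and the structure differs in a second place as well.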